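The compounds below may be only part of what the source reports. "The series", "measured", "known", "first", "only" and "open" are said of these compounds alone.

The measured compounds: compound 1, `O=C(O)c1ccccc1-c1ccc(CCc2ncc(Cc3ccccc3F)[nH]2)cc1`, gives 177 nM in an in vitro functional assay on cells for agonist activity at Bombesin receptor subtype-3 (Homo sapiens), read by luminescence and calcium flux; a higher number here means that more compound is needed for the effect, a lower number that less compound is needed; compound 2, `O=C(O)c1ccccc1-c1ccc(CCc2ncc(CC3CCCCCC3)[nH]2)cc1`, gives 88 nM; compound 3, `N#Cc1ccccc1Cc1cnc(CCc2ccc(-c3ccccc3C(=O)O)cc2)[nH]1`, gives 5480 nM.

Compound 3 stands highest of the three, needing the most compound, with a step of a 31-fold higher number from compound 1 to compound 3 (1.49 log units; beyond the scatter) and of a 62-fold higher number from compound 2 to compound 3 (1.79 log units; beyond the scatter), both beyond the scatter. Compound 4, `CC(C)(C)Cc1cnc(CCc2ccc(-c3ccccc3C(=O)O)cc2)[nH]1`, differs from compound 3 by tert-butyl in place of 2-cyanophenyl on a saturated chain carbon bound to an aromatic carbon. The step bearing most on this is a 62-fold higher number from compound 2 to compound 3 (1.79 log units; beyond the scatter), where a saturated ring in that place gave the lowest number of all; a 31-fold higher number from compound 1 to compound 3 (1.49 log units; beyond the scatter) points the same way. A large drop is therefore expected, roughly a 27-fold lower number from compound 3 to compound 4 (1.44 log units; beyond the scatter). Compound 4 is estimated at 200 nM, within 50 nM to 800 nM.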

Compound 4, half-maximal effective concentration: 106 nM
Beside the measured number, compound 4's estimate is 1.9-fold (0.28 log units) above it; the measured number falls inside the stated range.
By their numbers in this assay, from the lowest: compounds 2, 4 and 1 (each within the scatter of the next); then compound 3.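

In this assay, a 52-fold lower number from compound 3 to compound 4 (1.71 log units; beyond the scatter) shows that tert-butyl, which carries no ring, can take this place on the saturated chain carbon, and it reads alike with the two ring-bearing groups: a 1.2-fold higher number from compound 2 to compound 4 (0.08 log units; within the scatter) and a 1.7-fold lower number from compound 1 to compound 4 (0.22 log units; within the scatter) both lie within the scatter. A ring is therefore not required here, and among these four compounds only compound 3 stands apart. Nothing at hand explains the high number of compound 3.

Still open, as far as these compounds go, is how an amine, a carboxylic acid or a longer chain would read at this place, and whether a nitrile would raise the number on a group other than the phenyl ring.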